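From compound 1 to compound 3: a halogen exchange

The compounds below may be only part of what the source reports. "The series", "measured", "known", "first", "only" and "open" are said of these compounds alone.

Compound 1 `Cc1ccc(S/C(=C/c2ccc(Cl)c(Cl)c2)C(=O)c2ccc(Br)cc2)cc1` holds the highest of the two numbers measured in a functional assay on DU-145 cells (Homo sapiens) for inhibition, read by trypan blue exclusion, with a stated time of 96 h (a higher number here means a weaker inhibitor of growth, a lower number a stronger inhibitor of growth), where compound 1 gives 50000 nM. For the measured compounds named here, compound 2 `CCOc1cc(/C=C(\Cc2ccc(Cl)cc2Cl)C(=O)c2ccc(Cl)cc2)ccc1O` gives 10000 nM in this assay, a lower number lying beyond the scatter; no single-point step links these two, so only the pair of values is noted. Compound 3 `Cc1ccc(S/C(=C/c2ccc(F)cc2F)C(=O)c2ccc(Br)cc2)cc1` differs from compound 1 by 2,4-difluorophenyl in place of 3,4-dichlorophenyl on a double-bonded chain carbon bound to a double-bonded chain carbon. Going by the values given here, no measured step of this kind exists, so the change is expected to stay near the scatter, leaning toward a lower number. Compound 3 is estimated at 40000 nM, range 15000 nM to 100000 nM, a step of a 1.3-fold lower number from compound 1 to compound 3 (0.10 log units; within the scatter).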

Compound 3, concentration for 50% growth inhibition: > 100000 nM
Compound 3: only a limit was reported; the forecaster's own chance of this, stated with the estimate: 20%; middle value at least 2.5-fold (0.39 log units) away from the limit.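

In this assay compound 3 gives > 100000 nM, which is a limit of the assay and not a number. Placing 2,4-difluorophenyl in place of 3,4-dichlorophenyl gives the first single-point step in the series, an at least 2.0-fold higher number from compound 1 to compound 3 (0.30 log units; that floor lies within the scatter), and shows no lower number for this change. Only a floor can be read for the step, and its true size stays unknown: the limit of > 100000 nM in this assay, at which 1 of the 3 values shown sits.

On these data alone, the step changes the halogen and its ring positions together, so their separate contributions stay open. As far as these compounds go, how 3,4-difluorophenyl or an aminophenyl group would read at this place also stays open.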